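The compounds below may be only part of what the source reports. "The series", "measured", "known", "first", "only" and "open" are said of these compounds alone.

Within the data shown here, all three compounds measured so far share the core of compound 1, and none of them shows measurable cytotoxicity. In an ADME assay on HCT-116 cells (Homo sapiens) for cytotoxicity, read by CellTiter-Glo, with a stated time of 72 h (on this read-out lower numbers stand for stronger inhibition and higher numbers for weaker inhibition), compound 1 `Cc1noc(C)c1S(=O)(=O)N1CCC(N2CCC(C)CC2)CC1` reaches only the limit of the assay, reported as > 10000 nM. Compound 2 `CC1CCN(C2CCN(S(=O)(=O)c3cccc4cnccc34)CC2)CC1` likewise gives only a limit in this assay, at > 10000 nM. Compound 3 `CC1CCN(C2CCN(S(=O)(=O)c3ccc(OCc4ccccc4)cc3)CC2)CC1` also returns a limit, at > 5000 nM. Compound 1 therefore stands at the limit shared by two of the three values shown (the limit of > 10000 nM in this assay, at which 2 of the 3 values shown sit), while the third value rests at a different limit (the limit of > 5000 nM in this assay, at which 1 of the 3 values shown sits), so no ordering among the three can be drawn.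

Compound 4 `Cc1nc(Cl)sc1S(=O)(=O)N1CCC(N2CCC(C)CC2)CC1` differs from compound 1 in a single place: 2-chloro-4-methyl-1,3-thiazol-5-yl in place of 3,5-dimethyl-1,2-oxazol-4-yl on a sulfonyl sulfur. Among the measured compounds shown here, no step between two measured compounds is available here, so the effect of exchanging these two five-membered aromatic rings on the sulfonyl sulfur cannot be read off from any measured pair. Because compound 1 gives only a limit at > 10000 nM, compound 4 is expected to behave the same way, with the step that the limit leaves unreadable from compound 1 to compound 4 amounting to nothing beyond the usual scatter. Compound 4 is thus estimated at 20000 nM, within a range from 7000 nM to 60000 nM, and most probably it too will be reported only as a limit.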

Compound 4, half-maximal inhibitory concentration: > 10000 nM
Compound 4: only a limit was reported (the forecaster's own chance of this, stated with the estimate: 85%); the middle value is on the limit's open side.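

In this assay compound 4 gives > 10000 nM, which is a limit of the assay. Compound 1 also gives only a limit, so no step can be read between compound 1 and compound 4: the limit of > 10000 nM in this assay, at which 3 of the 4 values shown sit.

The compounds shown leave open how far any of them lies past its limit, and whether any group on the sulfonyl sulfur brings cytotoxicity into the measurable range.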